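Chain length and a sugar-linked core: from compound 3 to compound 4

The compounds below may be only part of what the source reports. "The series", "measured", "known", "first", "only" and "open" are said of these compounds alone.

Compound 1 `CCCCCCCCCCCCCCCCCC(=O)Nc1nnc(S[C@@H]2O[C@H](COC(C)=O)[C@H](OC(C)=O)[C@H](OC(C)=O)[C@H]2OC(C)=O)s1`: 44700 nM
Compound 2 `CCCCCCCC/C=C\CCCCCCCC(=O)Nc1nnc(S[C@@H]2O[C@H](COC(C)=O)[C@H](OC(C)=O)[C@H](OC(C)=O)[C@H]2OC(C)=O)s1`: 26300 nM
Compound 3 `CCCCCCCCCCCC(=O)Nc1nnc(S[C@@H]2O[C@H](CO)[C@H](O)[C@H](O)[C@H]2O)s1`: "not active" (no number reported)

Going by the values given here, in an ADME assay on CHO-K1 cells (Cricetulus griseus) for cytotoxicity, read by MTT assay, with a stated time of 24 h (on this read-out higher numbers stand for weaker inhibition and lower numbers for stronger inhibition), compound 1 gives 44700 nM and compound 2 gives 26300 nM; the one step between them, a 1.7-fold lower number from compound 1 to compound 2 (0.23 log units; within the scatter), is dec-1-en-1-yl in place of decyl on a saturated chain carbon, seven bonds along the chain from a carbonyl carbon. Compound 3 shares a different core with compound 4 `CCCCCCCCCCCCCC(=O)Nc1nnc(S[C@@H]2O[C@H](CO)[C@H](O)[C@H](O)[C@H]2O)s1`, and in this assay compound 3 is reported only as "not active" (no number reported), with no number. The change to compound 4 is ethyl in place of hydrogen on a saturated chain carbon, ten or more bonds along the chain from a carbonyl carbon. Among the compounds with values here, no measured step on the core of compound 3 bears on this change, and the step from compound 1 to compound 2 lies within the scatter. A weak read-out, or none, is therefore expected for compound 4 in this assay, estimated at 60000 nM within a range from 25000 nM to 150000 nM.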

Compound 4, half-maximal inhibitory concentration: "not active" (no number reported)
No number was reported for compound 4, so the estimate cannot be set against anything.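

Compound 3 and compound 4 are both reported only as "not active" in this assay, so no step can be read between them. No evidence bears on this result. The compounds shown leave open how chain length on this core affects the read-out.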